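Removing the Chloro Group From the Aryl of Compound 3

The compounds below may be only part of what the source reports. "The series", "measured", "known", "first", "only" and "open" are said of these compounds alone.

Measured compounds:
compound 1, `Cc1ccc(-c2ccnc(C(=O)Nc3ccc(Oc4ccnc5[nH]ccc45)cc3)n2)cc1`: 6140 nM
compound 2, `COc1ccc(-c2cc(C(=O)Nc3ccc(Oc4ccnc5[nH]ccc45)cc3)ncn2)cc1`: 9830 nM
compound 3, `O=C(Nc1ccc(Oc2ccnc3[nH]ccc23)cc1)c1cc(-c2ccc(Cl)cc2)ncn1`: 15600 nM

Three compounds share a common core and differ in the group carried by the aryl ring attached to it. In a functional assay on PC-3 cells (Homo sapiens) for cytotoxicity, read by MTT assay, with a stated time of 72 h (a higher number here means a weaker inhibitor, a lower number a stronger inhibitor), compound 3 gives 15600 nM, the highest of the three numbers. Compound 2 stands nearest, within the scatter of compound 3; compound 1 gives a lower number, beyond the scatter, but differs from compound 3 in more than one place, so only the two values themselves can be compared.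

Compound 4, `O=C(Nc1ccc(Oc2ccnc3[nH]ccc23)cc1)c1cc(-c2ccccc2)ncn1`, differs from compound 3 by hydrogen in place of chloro on an aromatic carbon. Within the data shown here, the one measured step that concerns the same carbon is a 1.6-fold higher number from compound 2 to compound 3 (0.20 log units; within the scatter), an exchange of one group for another that stayed within the scatter. Among the measured compounds shown here, no measured pair shows the outright loss of a substituent at that carbon, so the expectation rests on that single step alone. Compound 4 is therefore expected to sit within the scatter of compound 3, with an expected step of a 1.3-fold lower number from compound 3 to compound 4 (0.11 log units; within the scatter). Compound 4 is estimated at 12000 nM, with a range from 5000 nM to 30000 nM.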

Compound 4, half-maximal inhibitory concentration: 240 nM
The estimate for compound 4 lay 50-fold (1.70 log units) above the measured number, and the stated range ends above it.
By their numbers in this assay, from the lowest: compound 4; then compounds 1, 2 and 3 (each within the scatter of the next, the first and the last beyond it).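

In this assay, among these compounds, this carbon of the outer phenyl ring proves far more sensitive than the earlier compounds suggested: taking away the chloro gives a large change (a 65-fold lower number from compound 3 to compound 4 (1.81 log units; beyond the scatter)), and the comparison with the methoxy compound gives one of similar scale (a 41-fold lower number from compound 2 to compound 4 (1.61 log units; beyond the scatter)). Among the compounds shown here, the only earlier step at this carbon, the exchange of methoxy for chloro (a 1.6-fold higher number from compound 2 to compound 3 (0.20 log units; within the scatter)), stayed within the scatter, so it showed only that these two groups could not be told apart. Compound 4 now shows that this likeness did not mean the position was indifferent, since among compounds 2, 3 and 4 the large separation lies between the unsubstituted phenyl and the two substituted rings.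

Nothing among the data given accounts for this separation. The compounds shown leave open whether the low number of compound 4 needs hydrogen at this carbon or would survive a fluoro, a hydroxyl or an amine there, and whether removing the methyl from compound 1 would produce a step of the same kind on its own core.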